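The source may hold more compounds than are shown below. What is called first, only, known or untested is meant among the compounds shown, and "the series" means these compounds.

In a functional assay on the whole organism (Tail, strain ICR) with Mus musculus as the target, in the tail flick test, with a stated time of 120 min, at a dose of 6.25 umol/kg by the oral route (on this read-out higher numbers stand for a stronger effect at the one dose given and lower numbers for a weaker effect), compound 2 `CC(C)[C@H](NC(=O)CN(c1nc(Cl)nc2[nH]cnc12)C1CC1)C(=O)OCc1ccccc1` gives 9.26%, and compound 1 `O=C(CN(c1nc(Cl)nc2[nH]cnc12)C1CC1)NCC(=O)OCc1ccccc1` gives 8.04%, with a number 1.2 percentage points higher from compound 1 to compound 2 (within the scatter). Compound 2 thus stands beside compound 1, the two numbers lying within the scatter of each other. Compound 3 `NCCCC[C@H](NC(=O)CN(c1nc(Cl)nc2[nH]cnc12)C1CC1)C(=O)OCc1ccccc1` differs from compound 2 in one place: 4-aminobutyl in place of isopropyl on a saturated chain carbon bound to an amide-type nitrogen and a carbonyl carbon. For the measured compounds named here, the only step that touches this position is the one from compound 1 to compound 2, and it stayed within the scatter, so no step beyond the scatter is expected in this assay. Compound 3 is therefore estimated at 9%, between 1% and 20%. That expectation amounts to a number 0.3 percentage points lower from compound 2 to compound 3 (within the scatter).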

Compound 3, a percentage reported as activity, at one dose (the size of the read-out at that dose, not a potency): 9.01%
For compound 3 the middle estimate is 0 percentage points below the measured one, and the stated range covers the measured number.
By their numbers in this assay, from the lowest: compounds 1, 3 and 2 (each within the scatter of the next).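

In this assay, 4-aminobutyl on a saturated chain carbon bound to an amide-type nitrogen and a carbonyl carbon matches isopropyl, with a number 0.3 percentage points lower from compound 2 to compound 3 (within the scatter), and also matches hydrogen, with a number 1 percentage points higher from compound 1 to compound 3 (within the scatter). The position has now taken a chain bearing an amine as well as a branched carbon group, and neither gives a step beyond the scatter. No evidence is available that would explain this result. Going by these compounds, it remains open whether a carboxylic acid or a benzyl group on this carbon would give a step beyond the scatter.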